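This account rests on a few compounds, and the source may have more. Where it says the series, first, only, none or still open, it means among the compounds named here.

Among the compounds with values here, in a functional assay on MDA-MB-231 cells (Homo sapiens) for cytotoxicity, read by MTT assay, with a stated time of 72 h (a higher number here means a weaker inhibitor, a lower number a stronger inhibitor), compound 3 `CCCN1CCN(CCCCn2c3c(c4ccccc42)C(=O)c2c[n+]([O-])c4ccccc4c2C3=O)CC1` gives 2980 nM, the highest number of the three measured so far and so the weakest inhibitor among them. Compound 1 `CN1CCN(CCCCn2c3c(c4ccccc42)C(=O)c2c[n+]([O-])c4ccccc4c2C3=O)CC1` gives 110 nM, and compound 2 `O=C1c2c[n+]([O-])c3ccccc3c2C(=O)c2c1c1ccccc1n2CCN1CCCC1` gives 630 nM.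

The next compound, compound 4 `O=C1c2c[n+]([O-])c3ccccc3c2C(=O)c2c1c1ccccc1n2CCN1CCCCC1`, differs from compound 3 in one place: piperidin-1-yl in place of 2-(4-propylpiperazin-1-yl)ethyl on a saturated chain carbon, two bonds along the chain from an aromatic nitrogen. In words, piperidin-1-yl stands in place of 2-(4-propylpiperazin-1-yl)ethyl on a saturated chain carbon, two bonds along the chain from an aromatic nitrogen.

The closest guide is a 4.7-fold higher number from compound 2 to compound 3 (0.67 log units; beyond the scatter), a modest step beyond the scatter that exchanges pyrrolidin-1-yl for the same 2-(4-propylpiperazin-1-yl)ethyl at that place. The change to compound 4 runs the opposite way, though with piperidin-1-yl as the incoming group. A caution comes from a 5.7-fold higher number from compound 1 to compound 2 (0.76 log units; beyond the scatter), also modest, and from the large 27-fold higher number from compound 1 to compound 3 (1.43 log units; beyond the scatter): the outcome of such an exchange depends on the group being replaced.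

A modest fall in the number is therefore expected, with an estimated 4.8-fold lower number from compound 3 to compound 4 (0.68 log units; beyond the scatter). Compound 4 is expected near 620 nM, with an estimated range of 200 nM to 1900 nM.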

Compound 4, half-maximal inhibitory concentration: 1050 nM
Compound 4: the middle estimate sits 1.7-fold (0.23 log units) below what was measured; the range from low to high includes it.
By their numbers in this assay, from the lowest: compound 1; then compounds 2 and 4 (each within the scatter of the next); then compound 3.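

In this assay piperidin-1-yl and pyrrolidin-1-yl on this saturated chain carbon cannot be told apart (a 1.7-fold higher number from compound 2 to compound 4 (0.22 log units; within the scatter)), so a single change in the size of this amine ring leaves no measurable mark here. Replacing a piperazine chain with piperidin-1-yl has no single direction: it gives a 2.8-fold lower number from compound 3 to compound 4 (0.45 log units; beyond the scatter) when the chain is 2-(4-propylpiperazin-1-yl)ethyl, but a 9.5-fold higher number from compound 1 to compound 4 (0.98 log units; beyond the scatter) when it is 2-(4-methylpiperazin-1-yl)ethyl, so the result depends on the small alkyl group at the far end of the chain. Nothing available on these compounds explains these differences.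

Still open, as far as these compounds go, is whether a morpholin-4-yl group at this place would read like the two simple ring amines. It is also unknown how a 2-(4-ethylpiperazin-1-yl)ethyl group would compare with its methyl and propyl relatives.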